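Shifting the Chlorine: One Change Tried on Two Cores

The compounds below may be only part of what the source reports. "The series", "measured", "known", "first", "only" and "open" are said of these compounds alone.

Of the compounds shown here, three have been tested in an assay on isolated protein for inhibition of DNA topoisomerase 1 (Homo sapiens), with a stated time of 30 min, tested at 100 uM; a higher number here means a stronger effect of the compound at the concentration tested, a lower number a weaker effect. Compound 1 `Oc1ccc(-c2cc(-c3ccc(Cl)cc3)nc(-c3cccs3)c2)cc1` gives 38.8%. Compound 2 `Oc1ccc(-c2cc(-c3cccc(Cl)c3)nc(-c3cccs3)c2)cc1` gives 52.4%. The two differ by 3-chlorophenyl in place of 4-chlorophenyl on an aromatic carbon, and this change produced a number 13.6 percentage points higher from compound 1 to compound 2 (beyond the scatter).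

Compound 3 `Oc1cccc(-c2cc(-c3ccc(Cl)cc3)nc(-c3ccsc3)c2)c1` gives 11.7%, the lowest of the three numbers. How the core of compound 3 differs from the core of compound 1 is not broken down here. Compound 4 `Oc1cccc(-c2cc(-c3ccsc3)nc(-c3cccc(Cl)c3)c2)c1` has not yet been measured in this assay; it differs from compound 3 by 3-chlorophenyl in place of 4-chlorophenyl on an aromatic carbon. Among the measured compounds shown here, this is the same kind of change as the one from compound 1 to compound 2, but the surroundings are not identical: in compound 1 the place is meta to a 4-hydroxyphenyl group and meta to a thiophen-2-yl group, whereas in compound 3 it is meta to a 3-hydroxyphenyl group and meta to a thiophen-3-yl group. For the measured compounds named here, with only one measured example of the change, the expectation is a rise of similar size but with wide uncertainty. The step expected for compound 4 is a number 10.3 percentage points higher from compound 3 to compound 4 (beyond the scatter), resting on the rise seen for compound 2 in a number 13.6 percentage points higher from compound 1 to compound 2 (beyond the scatter). Compound 4 is therefore estimated at 22%, with a likely range from 8% to 40%.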

Compound 4, a percentage reported as inhibition, at one concentration (the size of the read-out at that concentration, not a potency): 26.2%
Compound 4: the middle estimate sits 4.2 percentage points below what was measured; low and high end bracket the measured number.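

In this assay, putting 3-chlorophenyl in place of 4-chlorophenyl on the core of compound 3 again raises the read-out, giving a number 14.5 percentage points higher from compound 3 to compound 4 (beyond the scatter). The change therefore carried from one core to the other with its size intact: the same change on two cores in this assay, a number 13.6 percentage points higher (beyond the scatter) from compound 1 to compound 2 and a number 14.5 percentage points higher (beyond the scatter) from compound 3 to compound 4, 0.9 percentage points apart, within the scatter of two such steps. Among the compounds shown here, this is still only two pairs, each read at a single concentration, so it shows neither that the same rise would appear on further cores nor why the chlorine's place matters, and it says nothing about potency.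

The compounds shown leave open whether the rise belongs to chlorine itself, since an amine, a methoxy group or a carboxylic acid on that phenyl ring appears in none of them. They also leave open how the hydroxyphenyl and thiophene groups each contribute, since the 4-hydroxyphenyl and thiophen-2-yl groups of compound 1 differ together from the 3-hydroxyphenyl and thiophen-3-yl groups of compound 3.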